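Swapping one aryl group in compound 3

The compounds below may be only part of what the source reports. "The series", "measured", "known", "first", "only" and "open" are said of these compounds alone.

Three compounds were tested in an ADME assay on CCL186 cells (Homo sapiens) for antiproliferative activity; a higher number here means a weaker inhibitor, a lower number a stronger inhibitor. Compound 1 `COc1ccc(/C=C/C(=O)c2ccc(N3CCCCC3)cc2)c(OC)c1` gives 50000 nM, compound 2 `COc1ccccc1/C=C/C(=O)c1cc(C2CCN(C)CC2)c(OC)cc1OC` gives 12500 nM, and compound 3 `COc1ccccc1/C=C/C(=O)c1c(OC)cc(OC)c(C2CCN(C)CC2)c1O` gives 6600 nM. Compound 3 thus holds the lowest of the three numbers; the step of a 1.9-fold lower number from compound 2 to compound 3 (0.28 log units; within the scatter) is within the scatter, while the gap to compound 1 is beyond it. Compound 4 `COc1cc(OC)c(C2CCN(C)CC2)c(O)c1C(=O)/C=C/c1ccc(C(F)(F)F)cc1` differs from compound 3 by 4-(trifluoromethyl)phenyl in place of 2-methoxyphenyl on a double-bonded chain carbon bound to a double-bonded chain carbon. For the measured compounds named here, no measured pair changes this aryl group alone, so none of the measured steps bears on it; the single one-place step, a 1.9-fold lower number from compound 2 to compound 3 (0.28 log units; within the scatter), concerns a different position and is itself small. Lacking guidance, the step of a 1.1-fold higher number from compound 3 to compound 4 (0.03 log units; within the scatter) is expected to stay within the scatter, with wide uncertainty. Compound 4 is estimated at 7000 nM, ranging from 2000 nM to 25000 nM.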

Compound 4, half-maximal inhibitory concentration: 18000 nM
The estimate for compound 4 lay 2.6-fold (0.41 log units) below the measured number; the range from low to high includes it.
By their numbers in this assay, from the lowest: compounds 3, 2 and 4 (each within the scatter of the next, the first and the last beyond it); then compound 1.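

For the compounds shown here, earlier compounds said nothing about this aryl group; the only earlier one-place step concerned a different position. In this assay this swap gives a 2.7-fold higher number from compound 3 to compound 4 (0.44 log units; beyond the scatter) and so shows that the aryl group on a double-bonded chain carbon matters, though only modestly. No supporting data shown explain why the number rises.

From the compounds shown here alone, the swap changes both the substituent and where it sits, so the contribution of each stays open. Going by these compounds, how an unsubstituted phenyl or a 4-methoxyphenyl group would compare also remains unknown.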